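Trimming a methoxy group: notes on compounds 1 to 4

The source may hold more compounds than are shown below. What is called first, only, known or untested is meant among the compounds shown, and "the series" means these compounds.

Three members of the series have been run in a functional assay on UACC-62 cells (Homo sapiens) for cytotoxicity, read by sulforhodamine B assay, with a stated time of 48 h, tested at 1 uM; on this read-out higher numbers stand for a weaker effect at the one concentration tested and lower numbers for a stronger effect. Compound 1 `COc1ccc(-c2cc(/C=C/C(=O)c3ccc(N)cc3)[nH]n2)cc1` gives 79% in this assay. Compound 2 `COc1ccc(-c2cc(/C=C/C(=O)c3ccc(N)cc3)[nH]n2)cc1OC` gives 95%. Compound 3 `COc1cc(C(=O)/C=C/c2cc(-c3cc(OC)c(OC)c(OC)c3)n[nH]2)cc(OC)c1OC` gives 90%; against compound 2 it lies within the scatter, while compound 1 stands lower by a margin beyond the scatter.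

One single-point change is measured, (hydrogen in place of methoxy on an aromatic carbon), and it made a number 16 percentage points lower from compound 2 to compound 1 (beyond the scatter). The difference between the core of compound 2 and the core of compound 3 is not broken down here.

Compound 4 `COc1ccc(-c2cc(/C=C/C(=O)c3cc(OC)c(OC)c(OC)c3)[nH]n2)cc1OC` has not yet been measured in this assay. It arises from compound 3 by hydrogen in place of methoxy on an aromatic carbon. This is the same kind of change as the measured one, not the same: in both the position is ortho to a methoxy group and meta to a large group, but in compound 3 it is also meta to a further methoxy group.

Among the compounds with values here, the only guide is the earlier step, a number 16 percentage points lower from compound 2 to compound 1 (beyond the scatter), which lies beyond the scatter. Within the data shown here, on that basis the step from compound 3 to compound 4 is expected to be a number 12 percentage points lower from compound 3 to compound 4 (beyond the scatter), a little tempered as the surroundings differ and only one instance exists. Compound 4 is thus expected to give about 78% in this assay. The expected range for compound 4 runs from 62% to 94%.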

Compound 4, a percentage reported as activity, at one concentration (the size of the read-out at that concentration, not a potency): 88%
Estimate against measurement, compound 4: 10 percentage points below; the measured number falls inside the stated range.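

In this assay, within the data shown here, hydrogen in place of methoxy on an aromatic carbon has now been read on two cores, and on the second it gave a number 2 percentage points lower from compound 3 to compound 4 (within the scatter), so on this core the change leaves no step that stands clear of repeated measurement. This does not show that the core alters the effect of the change, and it does not show that the effect carries over from one core to the other with its size intact: one step beyond the scatter and one within it, each resting on a single pair read at one concentration, cannot settle either reading. Set side by side, the two results cannot be told apart: the same change on two cores in this assay, a number 16 percentage points lower (beyond the scatter) from compound 2 to compound 1 and a number 2 percentage points lower (within the scatter) from compound 3 to compound 4, 14 percentage points apart, within the scatter of two such steps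

The compounds shown leave open how the same position behaves with groups other than methoxy and hydrogen, such as a hydroxy group, a fluorine atom or a longer ether chain like ethoxy. Also open is whether the step would hold on a third core, for instance one carrying a carboxylic acid in place of the amine of compound 1, and whether any of these compounds would separate more clearly at other concentrations.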